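Cyclopropyl in place of ethyl: notes on the series

This account rests on a few compounds, and the source may have more. Where it says the series, first, only, none or still open, it means among the compounds named here.

Measured in an ADME assay on Vero cells (Chlorocebus sabaeus) for cytotoxicity, read by CellTiter-Glo, with a stated time of 72 h; on this read-out higher numbers stand for lower toxicity in this test and lower numbers for higher toxicity in this test:
- compound 1 `[O-][n+]1nc(NC2CC2)[n+]([O-])c2ccccc21`: 21 ug/mL
- compound 2 `[O-][n+]1nc(NC2CC2)[n+]([O-])c2ccc(F)cc21`: 1.3 ug/mL
- compound 3 `CCNc1n[n+]([O-])c2cc(Cl)ccc2[n+]1[O-]`: 2.6 ug/mL

Compound 3 at 2.6 ug/mL lies within the scatter of compound 2 at 1.3 ug/mL. Its number is clearly lower than that of compound 1 at 21 ug/mL, a gap beyond the scatter.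

The next compound is compound 4 `[O-][n+]1nc(NC2CC2)[n+]([O-])c2ccc(Cl)cc21`, which has cyclopropyl in place of ethyl on a nitrogen on an aromatic ring. The rest of compound 3 is unchanged.

For the measured compounds named here, only one step between measured compounds is available, a 16-fold lower number from compound 1 to compound 2 (1.21 log units; beyond the scatter). It is large, but it is fluoro in place of hydrogen on an aromatic carbon, so it gives no direct measure of a change on the nitrogen. Going by the values given here, no measured pair isolates ethyl against cyclopropyl. Compound 2 carries cyclopropyl and compound 3 carries ethyl, and their values lie within the scatter of each other, though they also differ elsewhere. No shift beyond the scatter is therefore expected in this assay, and no direction can be firmly assigned.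

The expected change is a 1.3-fold lower number from compound 3 to compound 4 (0.11 log units; within the scatter).

For compound 4 the estimated value is 2 ug/mL, with an expected range from 0.7 ug/mL to 6 ug/mL.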

Compound 4, half-maximal cytotoxic concentration: 1.3 ug/mL
Estimate against measurement, compound 4: 1.5-fold (0.19 log units) above; the measured number falls inside the stated range.
By their numbers in this assay, from the lowest: compounds 2, 4 and 3 (each within the scatter of the next); then compound 1.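

The cyclopropyl and ethyl groups can now be compared directly on a nitrogen on an aromatic ring, with the chloro substituent held constant. In this assay this comparison gives (a 2.0-fold lower number from compound 3 to compound 4 (0.30 log units; within the scatter)), so this change on the nitrogen does not separate the pair beyond the scatter. With cyclopropylamino held constant, the chloro step (a 16-fold lower number from compound 1 to compound 4 (1.21 log units; beyond the scatter)) matches the fluoro step (a 16-fold lower number from compound 1 to compound 2 (1.21 log units; beyond the scatter)), and chloro in place of fluoro gives (no change at the digits printed from compound 2 to compound 4 (within the scatter)), so the large step from the hydrogen-bearing compound appears with both halogens and does not distinguish between them. No measurement offered here bears on the cause of these steps.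

Still open, as far as these compounds go, is whether a longer chain, such as n-butyl, or an amine-bearing chain, such as 2-(dimethylamino)ethyl, on the same nitrogen would move the number beyond the scatter. Also open, from the compounds shown here alone, are whether the match between ethyl and cyclopropyl holds with fluoro or hydrogen on the aromatic carbon, and whether a methoxy group at that carbon would give a number nearer that of the hydrogen-bearing compound or those of the two halogen compounds.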